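The source may hold more compounds than are shown below. What is called first, only, known or untested is meant among the compounds shown, and "the series" means these compounds.

Measured in a functional assay on SGC-7901 cells (Homo sapiens) for antiproliferative activity, read by MTT assay, with a stated time of 72 h; on this read-out lower numbers stand for stronger inhibition and higher numbers for weaker inhibition:
- compound 1 `CCOC(=O)c1cc(-c2cc(OC)c(OC)c(OC)c2)c(-c2ccc3ccccc3c2)s1`: 4340 nM
- compound 2 `COc1cc(-c2cc(C(=O)O)sc2-c2cccc(Br)c2)cc(OC)c1OC`: 93400 nM
- compound 3 `COc1cc(-c2cc(C(=O)O)sc2-c2ccc3ccccc3c2)cc(OC)c1OC`: 380 nM

Of these three, compound 3 has the lowest number, and its steps to the other two are beyond the scatter. Next is compound 4 `COc1cc(-c2ccsc2-c2ccc3ccccc3c2)cc(OC)c1OC`, which has hydrogen in place of carboxy on an aromatic carbon.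

The closest evidence is an 11-fold lower number from compound 1 to compound 3 (1.06 log units; beyond the scatter), a large step made on the same carboxy group. Capping that group with ethyl cost activity, but no measured compound lacks the group, so this step only suggests that it matters. The other step, a 250-fold lower number from compound 2 to compound 3 (2.39 log units; beyond the scatter), is also large but lies at the naphthalen-2-yl place. It bears only on how steep changes in this series can be.

A move to a higher number in this assay is therefore expected, roughly of the size seen with compound 1 at 4340 nM, though with wide uncertainty. The expected change is a 3.9-fold higher number from compound 3 to compound 4 (0.60 log units; beyond the scatter). Compound 4 is estimated at 1500 nM, with an expected range of 200 nM to 12000 nM.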

Compound 4, half-maximal inhibitory concentration: 5890 nM
Compound 4: middle estimate off by 3.9-fold (0.59 log units), on the low side, and the stated range covers the measured number.
By their numbers in this assay, from the lowest: compound 3; then compounds 1 and 4 (each within the scatter of the next); then compound 2.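

In this assay hydrogen in place of carboxy on the aromatic carbon next to the ring sulfur gives a 16-fold higher number from compound 3 to compound 4 (1.19 log units; beyond the scatter), a direct reading of the carboxy group against hydrogen at this place. Hydrogen in place of ethoxycarbonyl on the same carbon gives a 1.4-fold higher number from compound 1 to compound 4 (0.13 log units; within the scatter), so ethoxycarbonyl and hydrogen cannot be told apart here, and among the naphthalen-2-yl compounds only the free carboxy group stands apart. No measured property accompanies these numbers to account for the step.

The compounds shown leave open how an amide, a hydroxymethyl group or an amine would read on this aromatic carbon. Also open, on these data alone, is whether the carboxy group counts for as much with 3-bromophenyl in place of naphthalen-2-yl.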